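Changing the Sulfonyl Substituent in a Series Tolerated by Cells

The source may report more compounds than this note shows. Statements on the series, on what has been measured and on what is new or still open speak of the compounds shown alone.

Compound 1 `COc1ccc([C@H]2CC(=O)N(c3cccc(N(C)C)c3)C2)cc1OC1CCCC1` — a functional assay on HEK293 cells (Homo sapiens) for cytotoxicity; a lower number here means that less compound is tolerated, a higher number that more compound is tolerated: > 10000 nM
Compound 2 `COc1ccc([C@H]2CC(=O)N(c3cccc(C#N)c3)C2)cc1OC1CCCC1` — > 10000 nM
Compound 3 `COc1ccc([C@H]2CC(=O)N(c3cccc(NS(=O)(=O)c4cc(C)ccc4OC)c3)C2)cc1OC1CCCC1` — > 10000 nM

Each of the three measured compounds reaches only a limit of the assay, not a number. For compound 1 the reading > 10000 nM is such a limit. For compound 2 the reading > 10000 nM is likewise a limit. The step from compound 1 to compound 2, a step that the two limits leave unreadable from compound 1 to compound 2, therefore cannot be read, although it swaps cyano in place of dimethylamino on an aromatic carbon. Among the measured compounds shown here, compound 3, the closest neighbour of the new compound, also stands at a limit, > 10000 nM, so no step of any size is known around it; the evidence is summed up by the limit of > 10000 nM in this assay, at which 3 of the 3 values shown sit.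

Compound 4 `COc1ccc([C@H]2CC(=O)N(c3cccc(NS(=O)(=O)c4cc(Br)c(Cl)s4)c3)C2)cc1OC1CCCC1` differs from compound 3 in one place: 4-bromo-5-chlorothiophen-2-yl in place of 2-methoxy-5-methylphenyl on a sulfonyl sulfur. For the measured compounds named here, no measured step tells how such a change affects tolerance, and the three limits give no direction. Compound 4 is therefore expected to remain at or near the limit, with a step that the limit leaves unreadable from compound 3 to compound 4 that is not distinguishable from none. The estimate for compound 4 is 15000 nM, ranging from 7000 nM to 40000 nM.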

Compound 4, half-maximal cytotoxic concentration: > 10000 nM
Compound 4 gave a limit, no number; the forecaster's own chance of this, stated with the estimate: 85%; the middle value lies beyond the limit too.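

In this assay compound 4 gives > 10000 nM as a limit of the assay, not a number. Its steps from compound 1, compound 2 and compound 3 therefore cannot be read, and the values offer only this: the limit of > 10000 nM in this assay, at which 4 of the 4 values shown sit.

The compounds shown leave open where any of the four would give a number in this assay and whether changing the sulfonyl substituent would shift it.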